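The source may report more compounds than this note shows. Statements on the series, on what has been measured and on what is new or still open speak of the compounds shown alone.

Compound 1 `C/C(=N\NC(=O)c1cccc(S(=O)(=O)N2CCOCC2)c1)c1cccc(O)c1`: in a functional assay on MCF7 cells (Homo sapiens) for antiproliferative activity, read by MTT assay, with a stated time of 72 h (on this read-out lower numbers stand for stronger inhibition and higher numbers for weaker inhibition), compound 1 gives > 100000 nM, a limit of the assay.
Compound 2 `C/C(=N\NC(=O)c1cccc(S(=O)(=O)N2CCOCC2)c1)c1cc(Br)ccc1O`: in this assay compound 2 gives 7830 nM.

Within the data shown here, compound 2 thus holds the only actual number measured, while compound 1 sits at a limit rather than a number (the limit of > 100000 nM in this assay, at which 1 of the 2 values shown sits). Compound 3 `C/C(=N\NC(=O)c1cccc(S(=O)(=O)N2CCOCC2)c1)c1cccc(N)c1O` differs from compound 2 by 3-amino-2-hydroxyphenyl in place of 5-bromo-2-hydroxyphenyl on a carbon with a double bond to nitrogen. Among the measured compounds shown here, the single measured step, an at least 12-fold lower number from compound 1 to compound 2 (1.10 log units; beyond the scatter), moved the hydroxy group and added bromine at once, so it does not isolate the bromine-for-amino exchange made here. Compound 3 is expected to lose potency modestly, a 3.8-fold higher number from compound 2 to compound 3 (0.58 log units; beyond the scatter), with an estimated 30000 nM in this assay ranging from 8000 nM to 100000 nM.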

Compound 3, half-maximal inhibitory concentration: 1010 nM
Compound 3: middle estimate off by 30-fold (1.47 log units), on the high side; measured number below the stated range.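

At this position 3-amino-2-hydroxyphenyl outperforms 5-bromo-2-hydroxyphenyl, with a 7.8-fold lower number from compound 2 to compound 3 (0.89 log units; beyond the scatter), so bromine is not required for activity in this assay. Against 3-hydroxyphenyl the gain reaches an at least 99-fold lower number from compound 1 to compound 3 (1.99 log units; beyond the scatter). That step starts from a limit and not a number: the limit of > 100000 nM in this assay, at which 1 of the 3 values shown sits.

The compounds shown leave open whether the gain belongs to the amine itself or to where it sits on the ring. They also leave open whether a methoxy group or a carboxylic acid in its place would keep the gain.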